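The source may hold more compounds than are shown below. What is called first, only, known or untested is meant among the compounds shown, and "the series" means these compounds.

Measured so far:
Compound 1, `CC(C)(C)Cc1nn(CCC2CC2)c(=O)c(C2=NS(=O)(=O)c3cc(NS(C)(=O)=O)ccc3N2)c1O` — > 1000 nM
Compound 2, `CS(=O)(=O)Nc1ccc2c(c1)S(=O)(=O)N=C(c1c(O)c(C3=CCCC3)nn(CCC3CC3)c1=O)N2` — > 1000 nM

In an ADME assay on Huh-7 cells (Homo sapiens) for cytotoxicity, with a stated time of 72 h (on this read-out higher numbers stand for lower toxicity in this test and lower numbers for higher toxicity in this test), compound 1 gives > 1000 nM, which is a limit of the assay rather than a number. Compound 2 gives > 1000 nM, again only a limit. Accordingly the single measured step, a step that the two limits leave unreadable from compound 1 to compound 2, cannot be read, since the limit of > 1000 nM in this assay, at which 2 of the 2 values shown sit, is where both values sit. Compound 3, `CC(C)CCn1nc(CC(C)(C)C)c(O)c(C2=NS(=O)(=O)c3cc(NS(C)(=O)=O)ccc3N2)c1=O`, differs from compound 1 by isopropyl in place of cyclopropyl on a saturated chain carbon, two bonds along the chain from an aromatic nitrogen. Going by the values given here, no measured step speaks to this change, so compound 3 is expected to remain at the same limit, a step that the limit leaves unreadable from compound 1 to compound 3 being expected. Compound 3 is estimated at 1500 nM, with a range from 600 nM to 5000 nM.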

Compound 3, half-maximal cytotoxic concentration in the Huh-7 assay: > 1000 nM
Compound 3: a limit, no number; the forecaster's own chance of this, stated with the estimate: 85%; the middle value lies beyond the limit too.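

In a physicochemical assay for solubility, at pH 7.4 (a lower number here means a less soluble compound, a higher number a more soluble compound), compound 1 gives > 100000 nM, a limit of the assay and not a number. In the physicochemical assay compound 3 gives > 100000 nM, again only a limit. Going by these compounds alone, no step between compound 1 and compound 3 can be read in the Huh-7 assay or the physicochemical assay. The compounds shown leave open how large the effect of isopropyl in place of cyclopropyl is on either read-out.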